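The source may report more compounds than this note shows. Statements on the series, on what has been measured and on what is new or still open speak of the compounds shown alone.

Working notes on the side chain of this series, read in a functional assay on the whole organism with Rattus norvegicus as the target (a lower number here means that less compound is needed, a higher number that more compound is needed for the effect), across three measured compounds. Compound 1 `COC(=O)CC/C=C\CC[C@H]1C(=O)C[C@@H](O)[C@@H]1/C=C/C[C@@](C)(O)/C=C/C=C(C)C` stands at > 3.16 mg/kg (a limit of the assay, not a number). Compound 2 `C/C=C(C)\C=C\[C@](C)(O)C/C=C/[C@H]1[C@H](O)CC(=O)[C@@H]1CC/C=C\CCC(=O)OC` gives 1.23 mg/kg and compound 3 `C=C/C=C/[C@](C)(O)C/C=C/[C@H]1[C@H](O)CC(=O)[C@@H]1CC/C=C\CCC(=O)OC` gives 0.243 mg/kg (the lowest number of the set). The two steps into that lowest value are a 5.1-fold lower number from compound 2 to compound 3 (0.70 log units; beyond the scatter) (modest) and an at least 13-fold lower number from compound 1 to compound 3 (1.11 log units; beyond the scatter) (large).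

Compound 4 `C=C/C(C)=C/[C@](C)(O)C/C=C/[C@H]1[C@H](O)CC(=O)[C@@H]1CC/C=C\CCC(=O)OC` has not been measured. Its change is 2-methylbuta-1,3-dien-1-yl in place of buta-1,3-dien-1-yl on a saturated chain carbon bound to an oxygen on a saturated carbon and two saturated chain carbons.

Going by the values given here, no measured step makes this exact replacement. The closest guides are a 5.1-fold lower number from compound 2 to compound 3 (0.70 log units; beyond the scatter) and an at least 2.5-fold lower number from compound 1 to compound 2 (0.40 log units; beyond the scatter) (at least modest), where the groups differ from the one entering here, so they bear on it only in part. Across these three compounds, the vinyl compound has the lowest number and the methyl-bearing groups sit higher, with none going against this. A modest move to a higher number is therefore expected in this assay for the added methyl. The estimate is a 2.5-fold higher number from compound 3 to compound 4 (0.39 log units; beyond the scatter) (expected, not measured). Compound 4 is expected at 0.6 mg/kg (estimated range 0.2 mg/kg to 1.8 mg/kg).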

Compound 4, dose for half-maximal effect: 1.03 mg/kg
For compound 4 the middle estimate is 1.7-fold (0.23 log units) below the measured one; low and high end bracket the measured number.
By their numbers in this assay, from the lowest: compound 3; then compounds 4 and 2 (each within the scatter of the next). At a limit, above all of these: compound 1.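

In this assay, going by these compounds alone, the replacement of buta-1,3-dien-1-yl by 2-methylbuta-1,3-dien-1-yl on the saturated chain carbon bound to an oxygen gives the first reading for a single added methyl on the diene, and it is not neutral: a 4.2-fold higher number from compound 3 to compound 4 (0.63 log units; beyond the scatter). The further carbon of 3-methylpenta-1,3-dien-1-yl makes no readable difference against 2-methylbuta-1,3-dien-1-yl, with a 1.2-fold lower number from compound 2 to compound 4 (0.08 log units; within the scatter), so among these compounds the single methyl already accounts for the move away from the number of compound 3. Where the methyl stands on the chain still counts, since 4-methylpenta-1,3-dien-1-yl remains apart from 2-methylbuta-1,3-dien-1-yl, with an at least 3.0-fold lower number from compound 1 to compound 4 (0.48 log units; beyond the scatter), although compound 1 holds only a limit of the assay and not a number: the limit of > 3.16 mg/kg in this assay, at which 1 of the 4 values shown sits.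

On these data alone, whether any group at this place gives a lower number than compound 3 stays open, for instance a phenyl, a cyclopropyl or a hydroxymethyl in place of buta-1,3-dien-1-yl. The compounds shown also give no reading of a methyl on the terminal vinyl carbon of buta-1,3-dien-1-yl taken alone, and they give no reason for the step in this whole-organism read-out.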